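Dimethoxyphenyl Amide Gives Way to a Cyclohexenyl Amide

A few compounds are considered here, and "the series" means these few. Any claim that something is new, unique, unknown or untested is made for them only; others in the source may bear on it.

Compound 3 `COc1cc(OC)cc(C(=O)Nc2cc(-c3ccccc3)nn2-c2ccccc2)c1` gives 2040 nM in a functional assay on cells for positive allosteric modulation of metabotropic glutamate receptor 5 (Rattus norvegicus), read by calcium flux (on this read-out higher numbers stand for an effect only at larger amounts of compound and lower numbers for an effect already at smaller amounts), the highest number among the three measured compounds. Compound 1 `O=C(Nc1cc(-c2ccccc2)nn1-c1ccccc1)c1ccccc1` gives 203 nM, and compound 2 `COc1ccc(C(=O)Nc2cc(-c3ccccc3)nn2-c2ccccc2)cc1` gives 54 nM; between them, a 3.8-fold lower number from compound 1 to compound 2 (0.58 log units; beyond the scatter). The steps of a 10-fold higher number from compound 1 to compound 3 (1.00 log units; beyond the scatter) and a 38-fold higher number from compound 2 to compound 3 (1.58 log units; beyond the scatter) both lie beyond the scatter. Compound 4 `O=C(Nc1cc(-c2ccccc2)nn1-c1ccccc1)C1=CCCCC1` differs from compound 3 by cyclohex-1-en-1-yl in place of 3,5-dimethoxyphenyl on a carbonyl carbon. For the measured compounds named here, both steps onto the 3,5-dimethoxyphenyl raised the number, so its removal from the carbonyl carbon points toward a lower number; no measured compound carries a non-aromatic ring at that place, so the size is uncertain. Compound 4 is therefore expected to show a 3.4-fold lower number from compound 3 to compound 4 (0.53 log units; beyond the scatter). The estimate for compound 4 is 600 nM, with a range from 120 nM to 3000 nM.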

Compound 4, half-maximal effective concentration: 3300 nM
For compound 4 the middle estimate is 5.5-fold (0.74 log units) below the measured one, and the stated range ends below it.
By their numbers in this assay, from the lowest: compound 2; then compound 1; then compounds 3 and 4 (each within the scatter of the next).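

In this assay, cyclohex-1-en-1-yl on the carbonyl carbon reads the same as 3,5-dimethoxyphenyl within the scatter (a 1.6-fold higher number from compound 3 to compound 4 (0.21 log units; within the scatter)), so an aromatic ring is not needed to give a number at this level. The non-aromatic ring stands far from the phenyl and 4-methoxyphenyl amides (a 16-fold higher number from compound 1 to compound 4 (1.21 log units; beyond the scatter); a 61-fold higher number from compound 2 to compound 4 (1.79 log units; beyond the scatter)), and it does not reach the lower numbers of either. No evidence at hand bears on the reason for this result. From the compounds shown here alone, whether the double bond matters remains open, as a cyclohexyl group would test. So does how a piperidine ring would read at this place.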